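Swapping one sulfonamide arm for a nitrobenzamide

The source may report more compounds than this note shows. Statements on the series, on what has been measured and on what is new or still open speak of the compounds shown alone.

Measured compounds:
- compound 1, `O=S(=O)(Nc1ccc(-c2nc3cc(NS(=O)(=O)c4ccccc4Cl)ccc3o2)cc1)c1ccccc1Cl`, 15000 nM in a functional assay on HT-29 cells (Homo sapiens) for cytotoxicity, read by resazurin assay, with a stated time of 48 h; on this read-out higher numbers stand for an effect only at larger amounts of compound and lower numbers for an effect already at smaller amounts
- compound 2, `COc1ccc(S(=O)(=O)Nc2ccc3oc(-c4ccc(NS(=O)(=O)c5cc(F)ccc5OC)cc4)nc3c2)cc1`, 15000 nM in this assay
- compound 3, `Nc1ccc(S(=O)(=O)Nc2ccc(-c3nc4cc(NS(=O)(=O)c5ccc(N)cc5)ccc4o3)cc2)cc1`, 24000 nM in this assay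

All three compounds share the same core and carry two sulfonamide arms. In this assay compound 2 gives 15000 nM, level with compound 1 at the digits shown; together they hold the lowest numbers of the three. Compound 3 gives 24000 nM, a gap from compound 2 that stays within the scatter, so no order can be read among the three.

Compound 4, `COc1ccc(S(=O)(=O)Nc2ccc3oc(-c4ccc(NC(=O)c5cccc(C)c5[N+](=O)[O-])cc4)nc3c2)cc1`, has not yet been measured. Its change from compound 2 is a group of 12 heavy atoms (8 carbon, 1 nitrogen, 3 oxygen; one six-membered aromatic ring of carbon only) in place of a group of 12 heavy atoms (7 carbon, 3 oxygen, 1 fluorine, 1 sulfur; one six-membered aromatic ring of carbon only), on a nitrogen on an aromatic ring. One arm of compound 2 is thereby replaced with a (3-methyl-2-nitrophenyl)carbonyl group, on a nitrogen on an aromatic ring whose other neighbours are aromatic carbon. For the measured compounds named here, no measured pair here shows such an exchange, so no step size can be drawn from the data.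

Because compound 2 gives 15000 nM and the three measured compounds all sit close together, compound 4 is expected to stay near that level, and the step of no change at the digits printed from compound 2 to compound 4 (within the scatter) is estimated to lie within the scatter, with no clear direction. Compound 4 is therefore estimated at 15000 nM, with a range from 5000 nM to 45000 nM.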

Compound 4, half-maximal effective concentration: 2300 nM
Compound 4: the middle estimate sits 6.5-fold (0.81 log units) above what was measured; the whole stated range lies above it.
By their numbers in this assay, from the lowest: compound 4; then compounds 1, 2 and 3 (each within the scatter of the next).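

Exchanging one sulfonamide arm for a (3-methyl-2-nitrophenyl)carbonyl group, on a nitrogen on an aromatic ring, gives a 6.5-fold lower number from compound 2 to compound 4 (0.81 log units; beyond the scatter) in this assay, a step beyond the scatter. For the compounds shown here, the earlier compounds all carry two sulfonamide arms and sit within the scatter of one another, so this is the first sign that the number responds to what stands on this nitrogen. No measurement shown here explains the step.

The exchange alters the link to the ring and the groups on the ring together, and the compounds shown cannot separate these two parts. From the compounds shown here alone, a plain benzoyl group or an amine in place of the nitro group could help to separate them, and the effect of the same exchange on the other sulfonamide arm also remains open.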